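Benzyloxy in place of methoxy on an inactive series

A few compounds are considered here, and "the series" means these few. Any claim that something is new, unique, unknown or untested is made for them only; others in the source may bear on it.

Compound 2 `COc1ccc(-c2nnc(-c3c[nH]c4ccccc34)o2)cc1OC` is one of three close relatives built on a shared core. In a functional assay on PC-3 cells (Homo sapiens) for cytotoxicity, read by MTT assay (a higher number here means a weaker inhibitor, a lower number a stronger inhibitor), compound 2 gives only a limit, > 1000000 nM. Compound 1 `COc1ccc(-c2nnc(-c3c[nH]c4ccccc34)o2)cc1` likewise reaches only a limit in this assay, > 1000000 nM. Compound 3 `COc1ccc(-c2nnc(-c3c[nH]c4ccccc34)o2)c(OC)c1OC` also stops at a limit in this assay, > 1000000 nM. The steps a step that the two limits leave unreadable from compound 1 to compound 2 and a step that the two limits leave unreadable from compound 2 to compound 3 are thus unreadable, as the limit of > 1000000 nM in this assay, at which 3 of the 3 values shown sit, records. Compound 4 `COc1cc(-c2nnc(-c3c[nH]c4ccccc34)o2)ccc1OCc1ccccc1` differs from compound 2 by phenyl in place of hydrogen on a saturated chain carbon bound to an oxygen on an aromatic ring, so that methoxy becomes benzyloxy. For the measured compounds named here, no measured step bears on this change; all three measured compounds sit at the same limit. Compound 4 is expected to remain near that limit, with an expected step of a number no higher from compound 2 to compound 4 (the limit leaves the size open). The estimate for compound 4 is 1000000 nM, ranging from 200000 nM to 5000000 nM.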

Compound 4, half-maximal inhibitory concentration: > 1000000 nM
Compound 4 gave a limit, no number; the forecaster's own chance of this, stated with the estimate: 85%; the middle value lies on the limit itself.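

Compound 2 and compound 4 both stop at a limit in this assay, so no step can be read between them. The compounds shown leave open whether any change on the shared core would give a readable value.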